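The compounds below may be only part of what the source reports. "The series", "measured", "known", "first", "only" and "open" are said of these compounds alone.

In a toxicity assay on HaCaT cells (Homo sapiens) for inhibition (on this read-out lower numbers stand for stronger inhibition and higher numbers for weaker inhibition), compound 1 (`CC(C)c1cc(-c2n[nH]c(=O)n2-c2cccc(C(=O)NCCCCCCC(=O)NO)c2)c(O)cc1O`) gives > 6130 nM as a limit of the assay and not a number. Compound 2 (`CC(C)c1cc(-c2n[nH]c(=O)n2-c2ccc(C(=O)NCCCCCCCC(=O)NO)cc2)c(O)cc1O`) gives > 6130 nM and this too is a limit. Compound 1 therefore stands at the limit of > 6130 nM in this assay, at which 2 of the 2 values shown sit, with no number to place it. Compound 3 (`CNC(=O)CCCCCCCNC(=O)c1cccc(-n2c(-c3cc(C(C)C)c(O)cc3O)n[nH]c2=O)c1`) differs from compound 1 by (methylcarbamoyl)methyl in place of hydroxycarbamoyl on a saturated chain carbon, six bonds along the chain from an amide-type nitrogen with (methylcarbamoyl)methyl in place of hydroxycarbamoyl on a saturated chain carbon, six bonds along the chain from an amide-type nitrogen. In this assay, among the compounds with values here, the estimated step (a step that the limit leaves unreadable from compound 1 to compound 3) is expected to stay within the scatter, with no stronger inhibition, and this expectation rests only on the limit of > 6130 nM in this assay, at which 2 of the 2 values shown sit, as the sole evidence. Compound 3 is expected at 10000 nM with an estimated range from 6130 nM to 30000 nM on this read-out.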

Compound 3, half-maximal inhibitory concentration: > 6130 nM
Compound 3 ended at the assay's limit (the forecaster's own chance of this, stated with the estimate: 85%); the middle value does not contradict the limit.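

Within the data shown here, the values of compound 1 and compound 3 are both limits and not numbers, and no step between them can be read. The compounds shown leave open how strongly any of them inhibits in this assay, and whether (methylcarbamoyl)methyl in place of hydroxycarbamoyl changes that at all.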